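The source may hold more compounds than are shown below. What is called first, only, known or untested is meant among the compounds shown, and "the series" means these compounds.

Compound 1 `N#CC1=C(N)N(c2ccc(S(N)(=O)=O)cc2)C2=C(C(=O)CCC2)C1c1ccc(Cl)cc1Cl` gives 40% in a functional assay on Ehrlich cells (Mus musculus) for cytotoxicity, read by trypan blue exclusion, with a stated time of 2 h, tested at 10 ug/mL (a lower number here means a weaker effect, a higher number a stronger effect of the compound at the concentration tested), and stands highest of the two numbers measured here. Compound 2 `CC(Cl)CC(=O)NC1=C(C#N)C(c2ccc(Cl)cc2Cl)C2=C(CCCC2=O)N1c1ccc(S(N)(=O)=O)cc1` gives 20% in this assay; the step of a number 20 percentage points lower from compound 1 to compound 2 (beyond the scatter) comes with a (2-chloropropyl)carbonyl in place of hydrogen on an amine nitrogen. Compound 3 `NC(=O)C1=C(N)N(c2ccc(S(N)(=O)=O)cc2)C2=C(C(=O)CCC2)C1c1ccc(Cl)cc1Cl` differs from compound 1 at another spot: carbamoyl in place of cyano on a double-bonded ring carbon. Among the compounds with values here, the one measured step does not touch this part of the shared core, so it gives no direct guide, and the expected step of a number 5 percentage points lower from compound 1 to compound 3 (within the scatter) is small, within the scatter. Compound 3 is therefore expected to give about 35%, between 15% and 55%.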

Compound 3, a percentage reported as activity, at one concentration (the size of the read-out at that concentration, not a potency): 30%
Compound 3: the middle estimate sits 5 percentage points above what was measured; low and high end bracket the measured number.
By their numbers in this assay, from the lowest: compounds 2, 3 and 1 (each within the scatter of the next, the first and the last beyond it).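

At this double-bonded ring carbon, carbamoyl in place of cyano gives a number 10 percentage points lower from compound 1 to compound 3 (within the scatter) in this assay. The read-out therefore shows no clear change at this spot, even though carbamoyl, unlike cyano, counts a hydrogen-bond donor. No supporting measurement explains this result.

From the compounds shown here alone, whether a carboxylic acid, a methyl ester or a longer chain on this carbon would also leave the read-out unchanged stays open. So does what carbamoyl would do alongside the (2-chloropropyl)carbonyl group of compound 2.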